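The source may hold more compounds than are shown below. What is called first, only, known or untested is meant among the compounds shown, and "the series" means these compounds.

Working notes on the ester variation. The series shares the core of compound 3, `CCCCc1nc(C)c(CC(=O)OCC(C)C)c(=O)n1Cc1ccc(-c2ccccc2-c2noc(=O)[nH]2)cc1`. In an ADME assay on microsomes from liver (Mus musculus) for metabolic stability, with a stated time of 30 min (on this read-out higher numbers stand for a more stable compound and lower numbers for a less stable compound), compound 3 gives 7.7%. Compound 2, `CCCCOC(=O)Cc1c(C)nc(CCCC)n(Cc2ccc(-c3ccccc3-c3noc(=O)[nH]3)cc2)c1=O`, gives 10.2%, and compound 1, `CCCCc1nc(C(C)C)c(CC(=O)OC2CCCCC2)c(=O)n1Cc1ccc(-c2ccccc2-c2noc(=O)[nH]2)cc1`, gives 14.6%; both gaps to compound 3 are within the scatter. Going by the values given here, the only single-point step measured, a number 2.5 percentage points lower from compound 2 to compound 3 (within the scatter), concerns the ester alkyl group and stays within the scatter. Compound 4, `CCCCc1nc(C)c(CC(=O)OC2CCCCC2)c(=O)n1Cc1ccc(-c2ccccc2-c2noc(=O)[nH]2)cc1`, differs from compound 3 by cyclohexyl in place of isobutyl on an oxygen next to a carbonyl group. Among the compounds with values here, compound 1 carries the same cyclohexyl ester and gives 14.6%, but no single-point step connects it to compound 3 or compound 4, so that comparison is indirect. The expected step is a number 4.3 percentage points higher from compound 3 to compound 4 (within the scatter), a small rise at most. Compound 4 is therefore estimated at 12%, between 5% and 22%.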

Compound 4, percent of the compound remaining: 10.7%
Beside the measured number, compound 4's estimate is 1.3 percentage points above it; low and high end bracket the measured number.
By their numbers in this assay, from the lowest: compounds 3, 2, 4 and 1 (each within the scatter of the next).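

Cyclohexyl in place of isobutyl on an oxygen next to a carbonyl group gives a number 3 percentage points higher from compound 3 to compound 4 (within the scatter) and cyclohexyl in place of butyl gives a number 0.5 percentage points higher from compound 2 to compound 4 (within the scatter) in this assay so the ring and both open chains read alike at this position. Methyl in place of isopropyl on an aromatic carbon gives a number 3.9 percentage points lower from compound 1 to compound 4 (within the scatter) and thus adds a first single-point reading away from the ester. No supporting data bear on these steps.

Going by these compounds, whether an amide or a carboxylic acid in place of the ester would move the percent remaining stays open.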